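The source may hold more compounds than are shown below. What is called first, only, known or untested is meant among the compounds shown, and "the series" means these compounds.

Compound 1 `CS(=O)(=O)c1nn2cc(-c3cc4ccccc4o3)nc2s1` is one of two compounds that have been tested in an assay for antagonist activity at proteinase-activated receptor 4 (Homo sapiens), with stated times of 5 min, 50 s and 15 min, in the presence of a further agent that is not named here; a higher number here means a weaker inhibitor, a lower number a stronger inhibitor. In this assay compound 1 reaches only the limit of the measurement, > 30000 nM, so no number is known for it. The value of compound 1 stands at the limit of > 30000 nM in this assay, at which 1 of the 2 values shown sits. Among the measured compounds shown here, compound 2 `COc1nn2cc(-c3cc4ccc(OCc5ccccc5)cc4o3)nc2s1` differs from compound 1 in two places, and in this assay compound 2 gives 1800 nM; the two values show that compound 2 is the only one of the pair with a measured number.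

Compound 3 `Cc1nn2cc(-c3cc4ccccc4o3)nc2s1` has not yet been measured. It differs from compound 1 by methyl in place of methylsulfonyl on an aromatic carbon. For the measured compounds named here, no pair of measured compounds that differ in only this place is available, and compound 1 is known only as a limit, so the size of the step cannot be fixed from the data. The step of an at least 2.0-fold lower number from compound 1 to compound 3 (0.30 log units; that floor lies within the scatter) is expected to run toward stronger inhibition, but not far. Compound 3 is estimated to give about 15000 nM in this assay, within a range from 4000 nM to 40000 nM.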

Compound 3, half-maximal inhibitory concentration: > 30000 nM
Compound 3: a limit, no number; the forecaster's own chance of this, stated with the estimate: 40%; middle value at least 2.0-fold (0.30 log units) away from the limit.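

In this assay compound 3, like compound 1, gives only a limit and no number, so no step can be read between the two compounds: the limit of > 30000 nM in this assay, at which 2 of the 3 values shown sit.

The compounds shown leave open whether methyl or methylsulfonyl on this aromatic carbon goes with the stronger inhibition, and by how much.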